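Swapping the aryl group on the benzylamine arm of compound 1

The source may report more compounds than this note shows. Statements on the series, on what has been measured and on what is new or still open speak of the compounds shown alone.

The series rests on a shared core carrying a bis(trifluoromethyl)phenylsulfonamide joined through a three-carbon chain to a benzylic amine. Compound 1 `O=S(=O)(NCCCNCc1ccc(Cl)c(Cl)c1)c1cc(C(F)(F)F)cc(C(F)(F)F)c1` is measured in a functional assay on MCF7 cells (Homo sapiens) for inhibition, read by MTT assay, with a stated time of 72 h (on this read-out higher numbers stand for weaker inhibition of growth and lower numbers for stronger inhibition of growth), where compound 1 gives 2400 nM. Compound 2 `O=S(=O)(NCCCNCc1cccc2ccccc12)c1cc(C(F)(F)F)cc(C(F)(F)F)c1` gives 1400 nM, so compound 1 holds the highest of the two numbers recorded, and the change a 1.7-fold lower number from compound 1 to compound 2 (0.23 log units; within the scatter) lies within the scatter. Compound 3 `COc1cccc(CNCCCNS(=O)(=O)c2cc(C(F)(F)F)cc(C(F)(F)F)c2)c1` is not yet measured; relative to compound 1 it differs as follows: 3-methoxyphenyl in place of 3,4-dichlorophenyl on a saturated chain carbon bound to an amine nitrogen. For the measured compounds named here, the only measured step that bears on this is the change of the aryl group on the same chain carbon from compound 1 to compound 2, which stayed within the scatter. For compound 3 a step no larger than the scatter is therefore expected, a 1.2-fold higher number from compound 1 to compound 3 (0.07 log units; within the scatter), in either direction. Compound 3 is estimated at 2800 nM, between 1100 nM and 7500 nM.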

Compound 3, concentration for 50% growth inhibition: 2400 nM
For compound 3 the middle estimate is 1.2-fold (0.07 log units) above the measured one; low and high end bracket the measured number.
By their numbers in this assay, from the lowest: compounds 2, 1 and 3 (each within the scatter of the next).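

With the hydrogen-bond acceptor of 3-methoxyphenyl entering and both chlorines of 3,4-dichlorophenyl leaving on a saturated chain carbon bound to an amine nitrogen, this assay shows no change at the digits printed from compound 1 to compound 3 (within the scatter). Against the naphthalen-1-yl group, the same place gives a 1.7-fold higher number from compound 2 to compound 3 (0.23 log units; within the scatter), so all three aryl groups in compounds 1, 2 and 3 lie within the scatter of one another, and a substituent containing oxygen fits this flat picture as well as one containing chlorine. No supporting measurement is available to explain this result.

The compounds shown leave open whether a pyridin-3-yl or cyclohexyl group at this place would give a step beyond the scatter. They also leave open what a longer chain between the sulfonamide and the amine would do to the number.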